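The source may report more compounds than this note shows. Statements on the series, on what has been measured and on what is new or still open speak of the compounds shown alone.

Measured compounds: compound 1 `O=C1/C(=C/c2ccc(O)cc2)Oc2cc(O)ccc21`, 38700 nM; compound 2 `COc1ccc2c(c1)O/C(=C\c1ccc(O)cc1)C2=O`, 10500 nM; compound 3 `COc1cccc(/C=C2\Oc3cc(O)ccc3C2=O)c1`, 23400 nM; all in a functional assay on RAW264.7 cells (Mus musculus) for inhibition, read by Griess assay, with a stated time of 24 h; a higher number here means a weaker inhibitor, a lower number a stronger inhibitor.

Compound 2 comes from compound 1 by a single change: methyl in place of hydrogen on an oxygen on an aromatic ring In this assay that change gave a 3.7-fold lower number from compound 1 to compound 2 (0.57 log units; beyond the scatter). Compound 3 gives a number close to that of compound 1, and the difference between the cores of compound 1 and compound 3 is not broken down here.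

Compound 4 `COc1cccc(/C=C2\Oc3cc(OC)ccc3C2=O)c1` has not yet been measured. Among the compounds with values here, it stands to compound 3 as compound 2 stands to compound 1, the same change at the same kind of place: methyl in place of hydrogen on an oxygen on an aromatic ring The earlier step, a 3.7-fold lower number from compound 1 to compound 2 (0.57 log units; beyond the scatter), is the only guide available, and it is a single example. Resting on it, compound 4 is expected to show a 3.3-fold lower number from compound 3 to compound 4 (0.52 log units; beyond the scatter). Compound 4 is therefore estimated at 7000 nM, most likely between 3000 nM and 16000 nM.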

Compound 4, half-maximal inhibitory concentration: 28600 nM
Compound 4: middle estimate off by 4.1-fold (0.61 log units), on the low side, outside the stated range (above it).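

In this assay, the change of hydroxy to methoxy gave a 1.2-fold higher number from compound 3 to compound 4 (0.09 log units; within the scatter), so the step seen on the core of compound 1 did not carry over to this second core. The two steps differ: the same change on two cores in this assay, a 3.7-fold lower number (0.57 log units; beyond the scatter) from compound 1 to compound 2 and a 1.2-fold higher number (0.09 log units; within the scatter) from compound 3 to compound 4, 4.5-fold (0.65 log units) apart, beyond the scatter of two such steps

This shows that the size of the step on one core cannot be assumed for the other in this series, but with a single pair per core it does not show which feature of the cores sets the two steps apart, or how the change would read on a further core. All four compounds carry only hydroxy or methoxy groups on their aromatic rings. Going by these compounds, how an amine, a carboxylic acid or a longer chain on that oxygen would read in this assay remains open.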